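Chloromethyl to vinyl on the amide carbonyl of compound 2

The source may hold more compounds than are shown below. What is called first, only, known or untested is meant among the compounds shown, and "the series" means these compounds.

Three compounds that share a core carrying a phenoxyphenyl group have been tested so far in a functional assay on JeKo-1 cells (Homo sapiens) for inhibition, read by luminescence and CellTiter-Glo, with a stated time of 72 h; a lower number here means a stronger inhibitor, a higher number a weaker inhibitor. Compound 1 `O=C(CCl)Nc1ccc(Cn2nc(-c3ccc(Oc4ccccc4)cc3)cc2CO)cc1` gives 400 nM in this assay. Compound 2 `CCOC(=O)c1cc(-c2ccc(Oc3ccccc3)cc2)nn1Cc1cccc(NC(=O)CCl)c1` gives 400 nM in this assay, level with compound 1 at the digits shown and within the usual scatter of it. Compound 3 `C=CC(=O)N1CCCC(n2nc(-c3ccc(Oc4ccccc4)cc3)cc2C(=O)O)C1` returns only a limit of > 60000 nM in this assay, and this is one of the three values that sit at the limit of the limit of > 60000 nM in this assay, at which 1 of the 3 values shown sits. For the measured compounds named here, no step between two measured compounds that differ in one place exists in this set.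

The next compound, compound 4 `C=CC(=O)Nc1cccc(Cn2nc(-c3ccc(Oc4ccccc4)cc3)cc2C(=O)OCC)c1`, differs from compound 2 in one place: vinyl in place of chloromethyl on a carbonyl carbon whose other neighbour is an amide-type nitrogen, so that (chloromethyl)carbonyl becomes vinylcarbonyl. Going by the values given here, no measured pair shows this change, so the size of the step in this assay is uncertain, and a small loss, of the order of the scatter or a little beyond it, is what is expected. On that basis compound 4 is estimated at 800 nM in this assay, between 250 nM and 4000 nM, which means an expected step of a 2.0-fold higher number from compound 2 to compound 4 (0.30 log units; within the scatter).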

Compound 4, half-maximal inhibitory concentration: 7600 nM
For compound 4 the middle estimate is 9.5-fold (0.98 log units) below the measured one; the whole stated range lies below it.
By their numbers in this assay, from the lowest: compounds 1 and 2 (each within the scatter of the next); then compound 4. At a limit, above all of these: compound 3.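

For the compounds shown here, with the rest of compound 2 unchanged, the exchange of (chloromethyl)carbonyl for vinylcarbonyl in this assay gives a 19-fold higher number from compound 2 to compound 4 (1.28 log units; beyond the scatter), the first step in this set between compounds that differ in one place. The group on this carbonyl carbon, whose other neighbour is an amide-type nitrogen, therefore matters strongly to the read-out, even though chloromethyl and vinyl count the same number of heavy atoms. Nothing in the data shown bears on the reason for this step.

The compounds shown leave open whether another group on this carbonyl carbon, such as a methyl, a bromomethyl or a longer chain ending in an amine, would read closer to compound 2 or to compound 4. They also leave open whether the same exchange would move compound 1 by a similar amount.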